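The source may hold more compounds than are shown below. What is called first, only, known or untested is meant among the compounds shown, and "the series" means these compounds.

In a functional assay on SH-SY5Y cells (Homo sapiens), read by MTT assay, with a stated time of 24 h (on this read-out lower numbers stand for an effect already at smaller amounts and higher numbers for an effect only at larger amounts of compound), compound 2 `COc1ccc(Cl)cc1N(CC(=O)Nc1cccc2ccccc12)S(=O)(=O)c1ccccc1` gives 17400 nM, the higher of the two numbers recorded, while compound 1 `CCn1ccc2cc(NC(=O)CN(c3cc(Cl)ccc3OC)S(=O)(=O)c3ccccc3)ccc21` gives 2220 nM. Compound 3 `COc1ccc(Cl)cc1N(CC(=O)N1CCc2ccccc21)S(=O)(=O)c1ccccc1` reaches only a limit of this assay, > 20000 nM. The step of a 7.8-fold higher number from compound 1 to compound 2 (0.89 log units; beyond the scatter) lay beyond the scatter, whereas an at least 1.1-fold higher number from compound 2 to compound 3 (0.06 log units; that floor lies within the scatter) ran into the ceiling described by the limit of > 20000 nM in this assay, at which 1 of the 3 values shown sits. Compound 4 `CCCNC(=O)CN(c1cc(Cl)ccc1OC)S(=O)(=O)c1ccccc1` changes the same end of the molecule once more: propyl in place of naphthalen-1-yl on an amide-type nitrogen. Both measured steps at that end moved toward an effect only at larger amounts, so a further step of that kind is expected, a 1.4-fold higher number from compound 2 to compound 4 (0.16 log units; within the scatter), with a real chance that compound 4 again reaches only the limit. Compound 4 is therefore estimated at 25000 nM, between 8000 nM and 80000 nM.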

Compound 4, half-maximal effective concentration: > 20000 nM
Compound 4 gave a limit, no number; the forecaster's own chance of this, stated with the estimate: 55%; the middle value is on the limit's open side.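

In this assay compound 4 gives > 20000 nM as a limit and not a number: the limit of > 20000 nM in this assay, at which 2 of the 4 values shown sit. On this amide-type nitrogen propyl, which has no ring, still leaves an at least 9.0-fold higher number from compound 1 to compound 4 (0.95 log units; beyond the scatter), so this open chain does not restore what 1-ethyl-1H-indol-5-yl gives. Set against naphthalen-1-yl, it shows an at least 1.1-fold higher number from compound 2 to compound 4 (0.06 log units; that floor lies within the scatter), and the step from compound 3 to compound 4 cannot be read, since both are limits. Open, as far as these compounds go, is whether an amine or a carboxylic acid at the end of a longer chain on this nitrogen would bring a readable number.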